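Aryl urea variation on the shared core: compound 3 to compound 4

A few compounds are considered here, and "the series" means these few. Any claim that something is new, unique, unknown or untested is made for them only; others in the source may bear on it.

Three ureas on the shared core of compound 1 `COc1cc(Cl)cc(-c2nn(-c3cccc(NC(=O)Nc4ccc(Cl)c(C(F)(F)F)c4)c3)cc2-c2ccncc2)c1` have been measured in a functional assay on T47D cells (Homo sapiens) for inhibition, read by sulforhodamine B assay, with a stated time of 48 h, tested at 1 uM; a lower number here means a stronger effect, a higher number a weaker effect of the compound at the concentration tested. Compound 1 gives 58%. Compound 2 `COc1cc(Cl)cc(-c2nn(-c3cccc(NC(=O)Nc4cc(C(F)(F)F)cc(C(F)(F)F)c4)c3)cc2-c2ccncc2)c1` gives 15% in this assay. Compound 3 `COc1cc(Cl)cc(-c2nn(-c3cccc(NC(=O)Nc4ccc(Cl)c(Cl)c4)c3)cc2-c2ccncc2)c1` gives 87%, the highest of the three numbers; compound 1 is nearest, compound 2 furthest, both beyond the scatter. Among the measured compounds shown here, the one single-point step measured, a number 29 percentage points higher from compound 1 to compound 3 (beyond the scatter), is the only one that bears directly on the change now followed.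

Compound 4 `COc1cc(Cl)cc(-c2nn(-c3cccc(NC(=O)Nc4cccc(C(F)(F)F)c4)c3)cc2-c2ccncc2)c1` differs from compound 3 as follows: 3-(trifluoromethyl)phenyl in place of 3,4-dichlorophenyl on an amide-type nitrogen. For the measured compounds named here, this reverses the direction of the measured step (trifluoromethyl now enters where chloro stood) and at the same time removes the second chloro, which no measured pair isolates. Going by the values given here, compound 2, carrying two trifluoromethyl groups, sits lowest of all, but no step is measured from it to any other compound, so only its value can be noted.

On the measured step alone, a downward move of roughly its size is expected for compound 4, as a number 27 percentage points lower from compound 3 to compound 4 (beyond the scatter), with added uncertainty from the unmeasured loss of the second chloro. Compound 4 is therefore estimated at 60%, expected between 35% and 85% in this assay.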

Compound 4, a percentage reported as activity, at one concentration (the size of the read-out at that concentration, not a potency): 58%
Estimate against measurement, compound 4: 2 percentage points above; low and high end bracket the measured number.
By their numbers in this assay, from the lowest: compound 2; then compounds 1 and 4 (each within the scatter of the next); then compound 3.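

On the aryl urea in this assay, the two groups added to the 3-(trifluoromethyl)phenyl of compound 4 now read differently: the chloro step gives no change at the digits printed from compound 1 to compound 4 (within the scatter) and so shows no measurable contribution from chloro, whereas the trifluoromethyl step gives a number 43 percentage points higher from compound 2 to compound 4 (beyond the scatter) and so marks a large move to a weaker effect on its removal. The change on the amide-type nitrogen gives a number 29 percentage points lower from compound 3 to compound 4 (beyond the scatter) as a stronger effect at the concentration tested, and this is the second modest step in this series where a trifluoromethyl group takes the place of a chloro group and the number falls, although here the second chloro is lost as well. Nothing available explains why the second chloro and the second trifluoromethyl group differ in this way.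

Open, from the compounds shown here alone, is whether a nitrile or a methoxy group in place of the second trifluoromethyl group of compound 2 would hold the stronger effect, or whether that effect is tied to trifluoromethyl itself. Also open, going by these compounds, is how the phenyl urea without any substituent, or one carrying a carboxylic acid or an amine, would read against compound 4 on the shared core.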